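Notes on methyl in place of dimethylamino

This account rests on a few compounds, and the source may have more. Where it says the series, first, only, none or still open, it means among the compounds named here.

- compound 1 `COc1cc(-c2nc(N(C)C)sc2-c2ccc(C(F)(F)F)cc2)cc(OC)c1OC`: > 10000 nM
- compound 2 `COc1ccc(-c2sc(N(C)C)nc2-c2cc(OC)c(OC)c(OC)c2)cc1`: 8360 nM

Among the compounds with values here, in a functional assay on MCF7 cells (Homo sapiens) for antiproliferative activity, read by MTT assay, with a stated time of 72 h (a higher number here means a weaker inhibitor, a lower number a stronger inhibitor), compound 2 gives 8360 nM, the only actual number so far. Compound 1 is reported only as a limit, > 10000 nM. The next structure is compound 3 `COc1ccc(-c2sc(C)nc2-c2cc(OC)c(OC)c(OC)c2)cc1`, which carries methyl in place of dimethylamino on an aromatic carbon of the shared core: methyl in place of dimethylamino on an aromatic carbon.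

Within the data shown here, the only measured step is an at least 1.1-fold lower number from compound 1 to compound 2 (0.07 log units; that floor lies within the scatter). It exchanges methoxy for trifluoromethyl, a different group from the one changing here, and its floor lies within the scatter. Among the measured compounds shown here, it therefore offers no size or direction for this change, and no measured step touches the dimethylamino group. No step beyond the scatter is expected in this assay, with no firm direction, and the range is kept wide. The expected step is a 1.7-fold lower number from compound 2 to compound 3 (0.22 log units; within the scatter). A report of a limit alone also remains possible, as the top of the range already holds (the limit of > 10000 nM in this assay, at which 1 of the 2 values shown sits). For compound 3 the estimated value is 5000 nM, with an expected range from 800 nM to 20000 nM.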

Compound 3, half-maximal inhibitory concentration: 606 nM
The estimate for compound 3 lay 8.3-fold (0.92 log units) above the measured number, and the stated range ends above it.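

In this assay, the aromatic carbon next to the ring nitrogen and next to the ring sulfur proves sensitive to its substituent: methyl in place of dimethylamino gives a 14-fold lower number from compound 2 to compound 3 (1.14 log units; beyond the scatter), the first step in the series shown to lie beyond the scatter. Compound 1 and compound 2 both carry dimethylamino here, so they gave no reading of this position, and the size of the step now shows that this place matters at least as much as the aryl group exchanged between them. The change swaps dimethylamino for a methyl with fewer heavy atoms and no hydrogen-bond acceptor, but nothing measured here separates these differences or accounts for the step.

Going by these compounds, with only dimethylamino and methyl at this position, it remains open whether the gain belongs to methyl itself or would also appear with ethyl, a longer chain or a primary amine. On these data alone, it is also open whether methyl gives a similar step alongside the 4-trifluoromethylphenyl group of compound 1, as the 4-methoxyphenyl group is the only partner seen with methyl.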